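Leaving the carboxypyrrolidine on the sulfonyl sulfur

A few compounds are considered here, and "the series" means these few. Any claim that something is new, unique, unknown or untested is made for them only; others in the source may bear on it.

Measured in an ADME assay on microsomes (Homo sapiens) for metabolic stability (a higher number here means faster removal of the compound, a lower number slower removal), so far:
- compound 1 `CNC(=O)[C@@H]1CCCN1S(=O)(=O)c1ccc(Cl)c(COc2cccc3c(-n4ccnc4)cc(C)nc23)c1Cl` at 33.3 mL/min/kg
- compound 2 `CCc1cc(C(F)(F)F)c2cccc(OCc3c(Cl)ccc(S(=O)(=O)N4CCC[C@H]4C(=O)NC)c3Cl)c2n1` at 300 mL/min/kg
- compound 3 `Cc1cc(C(F)(F)F)c2cccc(OCc3c(Cl)ccc(S(=O)(=O)N4CCC[C@H]4C(=O)O)c3Cl)c2n1` at 8.33 mL/min/kg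

Compound 3 stands lowest of the three, and both other numbers lie beyond the scatter from it. Compound 4 `Cc1cc(C(F)(F)F)c2cccc(OCc3c(Cl)ccc(S(=O)(=O)N4CCC(CCO)CC4)c3Cl)c2n1` carries 4-(2-hydroxyethyl)piperidin-1-yl in place of 2-carboxypyrrolidin-1-yl on a sulfonyl sulfur and is not yet measured. For the measured compounds named here, no measured step isolates this change. Neither compound 1 at 33.3 mL/min/kg nor compound 2 at 300 mL/min/kg carries the 2-carboxypyrrolidin-1-yl group, though both differ elsewhere too, so a rise beyond the scatter is expected. The expected size is a 7.2-fold higher number from compound 3 to compound 4 (0.86 log units; beyond the scatter) in this assay as estimated here. The estimate for compound 4 is 60 mL/min/kg (range 20 mL/min/kg to 180 mL/min/kg).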

Compound 4, clearance: 367 mL/min/kg
Estimate against measurement, compound 4: 6.1-fold (0.79 log units) below; the measured number lies above the stated range.
By their numbers in this assay, from the lowest: compound 3; then compound 1; then compounds 2 and 4 (each within the scatter of the next).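

In this assay, 4-(2-hydroxyethyl)piperidin-1-yl in place of 2-carboxypyrrolidin-1-yl on a sulfonyl sulfur gives a 44-fold higher number from compound 3 to compound 4 (1.64 log units; beyond the scatter) on an otherwise unchanged core. For the compounds shown here, this is the first single-place comparison, and it shows that the group at this position alone can produce a large change in clearance. Nothing available explains the size of this step.

As far as these compounds go, the change alters the ring, the carboxyl group and the side chain together, so their separate contributions remain open. A piperidine carrying a carboxylic acid would begin to separate them.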